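Exchanging the urea aryl group in a weak PC-3 series

The source may hold more compounds than are shown below. What is called first, only, known or untested is meant among the compounds shown, and "the series" means these compounds.

Compound 1 `COc1ccc(NC(=O)Nc2nc(Sc3c[nH]c4ccccc34)cc(N3CCCCC3)n2)cc1` and compound 2 `COc1ccc(NC(=O)Nc2nc(Sc3c[nH]c4ccccc34)cc(N3CCN(c4ccccn4)CC3)n2)cc1` share one core and differ only at the ring attached to the core. In a functional assay on PC-3 cells (Homo sapiens) for inhibition, with a stated time of 72 h (on this read-out higher numbers stand for weaker inhibition and lower numbers for stronger inhibition), compound 1 gives 17400 nM, and compound 2 gives 33400 nM; the step of a 1.9-fold higher number from compound 1 to compound 2 (0.28 log units; within the scatter) places compound 1 alongside compound 2 rather than apart from it. Compound 3 `Cc1ccc(C)c(NC(=O)Nc2nc(Sc3c[nH]c4ccccc34)cc(N3CCCCC3)n2)c1` keeps the piperidin-1-yl group of compound 1 and changes the other end: 2,5-dimethylphenyl in place of 4-methoxyphenyl on an amide-type nitrogen. Within the data shown here, no measured step touches this part of the molecule, since the only step available, from compound 1 to compound 2, concerns the group on the aromatic carbon and was itself within the scatter. With nothing to point either way, the step of a 1.0-fold lower number from compound 1 to compound 3 (0.01 log units; within the scatter) is expected to stay within the scatter. Compound 3 is therefore estimated at 17000 nM in this assay, with a range from 6000 nM to 50000 nM.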

Compound 3, half-maximal inhibitory concentration: > 50000 nM
Compound 3 ended at the assay's limit; the forecaster's own chance of this, stated with the estimate: 15%; at least 2.9-fold (0.46 log units) between middle value and limit.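

In this assay, putting 2,5-dimethylphenyl in place of 4-methoxyphenyl on the amide-type nitrogen gives an at least 2.8-fold higher number from compound 1 to compound 3 (0.45 log units; beyond the scatter). Among these compounds, this is the only step here that lies beyond the scatter, unlike the change on the aromatic carbon, which gave a 1.9-fold higher number from compound 1 to compound 2 (0.28 log units; within the scatter). The value of compound 3 is a limit of the assay and not a number, so the step has a known direction but no known full size: the limit of > 50000 nM in this assay, at which 1 of the 3 values shown sits.

The pair cannot separate the loss of the methoxy group from the arrival of the two methyl groups, and a 4-methylphenyl or unsubstituted phenyl group on the same nitrogen would bear on that question. As far as these compounds go, whether the same exchange has a similar effect alongside the 4-(pyridin-2-yl)piperazin-1-yl group of compound 2 also remains open.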